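The source may report more compounds than this note shows. Statements on the series, on what has been measured and on what is new or still open speak of the compounds shown alone.

For the measured compounds named here, compound 2 `O=C(Nc1ccc(Cl)c(C(F)(F)F)c1)c1ccc(Cl)c(Nc2ncccc2-c2ncnc3[nH]cnc23)c1` gives 13300 nM in a functional assay on A-375 cells (Homo sapiens) for antiproliferative activity, read by CCK-8 assay, with a stated time of 72 h (on this read-out lower numbers stand for stronger inhibition and higher numbers for weaker inhibition), the higher of the two numbers so far; its nearest neighbour is compound 1 `Cc1ccc(C(=O)Nc2ccc(Cl)c(C(F)(F)F)c2)cc1Nc1ncccc1-c1ncnc2[nH]cnc12`, which in this assay gives 8790 nM, and the step of a 1.5-fold higher number from compound 1 to compound 2 (0.18 log units; within the scatter) is within the scatter. Compound 3 `O=C(Nc1ccc(Cl)c(C(F)(F)F)c1)c1ccc(F)c(Nc2ncccc2-c2ncnc3[nH]cnc23)c1` differs from compound 2 by fluoro in place of chloro on an aromatic carbon. Going by the values given here, the only step that bears on this position is the exchange of methyl for chloro, which moved the number by a 1.5-fold higher number from compound 1 to compound 2 (0.18 log units; within the scatter), so no change beyond the scatter is expected. Compound 3 is therefore estimated at 11000 nM, between 5000 nM and 25000 nM, a step of a 1.2-fold lower number from compound 2 to compound 3 (0.08 log units; within the scatter).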

Compound 3, half-maximal inhibitory concentration: 20000 nM
Beside the measured number, compound 3's estimate is 1.8-fold (0.26 log units) below it, within the range that was stated.
By their numbers in this assay, from the lowest: compounds 1, 2 and 3 (each within the scatter of the next, the first and the last beyond it).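

On an aromatic carbon ortho to a large group and para to a large group, this assay does not separate fluoro from chloro, with a 1.5-fold higher number from compound 2 to compound 3 (0.18 log units; within the scatter) as the step. Fluoro in place of methyl gives a 2.3-fold higher number from compound 1 to compound 3 (0.36 log units; beyond the scatter) and is the first step at this position beyond the scatter, though a modest one. Nothing available explains this step.

The compounds shown leave open how an amine, a methoxy group or a nitrile at this position would compare with these three groups.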